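Cyclopentyl for Isopropyl on a Weak Modulator

The compounds below may be only part of what the source reports. "The series", "measured", "known", "first", "only" and "open" are said of these compounds alone.

compound 1 `COC(=O)c1ccc(OCCCCOc2ccc(C(=O)CC3CCCC3)c(C)c2C)cc1` — "not determined" (no result reported)
compound 2 `Cc1c(OCCCCOc2ccc(C(=O)O)c(Cl)c2)ccc(C(=O)CC(C)C)c1C` — > 10000 nM

Two measured compounds share a core in which a chain links two aromatic parts, one carrying a ketone with a branched side chain. In an assay on HEK293 cells for positive allosteric modulation of metabotropic glutamate receptor 2 (Rattus norvegicus), read by thallium flux, with a stated time of 2.5 min (on this read-out lower numbers stand for an effect already at smaller amounts and higher numbers for an effect only at larger amounts of compound), compound 1 has no reported result. For compound 2 in this assay the value > 10000 nM is a limit of the assay and not a number. On the numbers shown, compound 2 therefore stands only at that limit, where (the limit of > 10000 nM in this assay, at which 1 of the 2 values shown sits).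

Compound 3 `Cc1c(OCCCCOc2ccc(C(=O)O)c(Cl)c2)ccc(C(=O)CC2CCCC2)c1C` differs from compound 2 in one place: cyclopentyl in place of isopropyl on a saturated chain carbon bound to a carbonyl carbon. For the measured compounds named here, no step between two measured compounds is known here, so the effect of this change cannot be read from a measured pair. Compound 1 carries the same cyclopentyl group but differs elsewhere and gives no number, so it offers no guide.

The expectation is that compound 3 stays at or near the limit, and the estimated step of a number no higher from compound 2 to compound 3 (the limit leaves the size open) is expected to be none beyond the scatter. Compound 3 is estimated at 10000 nM, with a range from 3000 nM to 30000 nM, and a strong chance that again only a limit is reported.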

Compound 3, half-maximal effective concentration: 2420 nM
Estimate against measurement, compound 3: 4.1-fold (0.62 log units) above; the measured number lies below the stated range.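

In this assay, cyclopentyl in place of isopropyl on a saturated chain carbon bound to a carbonyl carbon gives an at least 4.1-fold lower number from compound 2 to compound 3 (0.61 log units; beyond the scatter), so the read-out does respond to the group at this position. Neither group carries a hydrogen-bond donor, a hydrogen-bond acceptor or a net charge; the change is from 3 heavy atoms with no ring to 5 heavy atoms in one five-membered ring of carbon only. From the compounds shown here alone, the true size of the step remains open-ended, because compound 2 stands at a limit and not at a number: the limit of > 10000 nM in this assay, at which 1 of the 3 values shown sits.

Going by these compounds, whether the ring itself matters or only the added carbons remains open, and a cyclohexyl group or an open pentyl chain at this position would help to separate the two. On these data alone, compound 1 also carries cyclopentyl but has no reported result, so it also remains open whether the same change would give a similar step when the rest of the molecule differs, for example with a methyl ester in place of the carboxylic acid.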